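The compounds below may be only part of what the source reports. "The series", "measured", "known", "first", "only" and "open" are said of these compounds alone.

Compound 1 `CC(=O)OCc1ccc2oc(=O)c(C(=O)Oc3cccc(Br)c3)cc2c1` is one of three compounds that share a core and differ only in the group attached to the carbonyl carbon. In a functional assay on HT-1080 cells (Homo sapiens), read by transwell migration, with a stated time of 24 h, tested at 0.1 uM (a lower number here means a stronger effect, a higher number a weaker effect of the compound at the concentration tested), compound 1 gives 39.5%. Compound 2 `CC(=O)OCc1ccc2oc(=O)c(C(=O)Sc3cccc(Cl)c3)cc2c1` gives 76.5% in this assay, and compound 3 `CC(=O)OCc1ccc2oc(=O)c(C(=O)Sc3cccc(Br)c3)cc2c1` gives 79.6%. Compound 1 thus has the lowest number of the three: the change to compound 2 reads a number 37 percentage points higher from compound 1 to compound 2 (beyond the scatter), and the change to compound 3 reads a number 40.1 percentage points higher from compound 1 to compound 3 (beyond the scatter). Between compound 2 and compound 3 the exchange of the halogen gives only a number 3.1 percentage points higher from compound 2 to compound 3 (within the scatter).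

Compound 4 `CCC(=O)OCc1ccc2oc(=O)c(C(=O)Oc3cccc(Br)c3)cc2c1` keeps the 3-bromophenoxy group of compound 1 and differs from it at another place: methyl in place of hydrogen on a saturated chain carbon bound to a carbonyl carbon. Cut one bond further out, the acetyl becomes a propanoyl, the acetoxy a propanoyloxy. For the measured compounds named here, none of the measured steps touches this place; the two large steps concern the group on the carbonyl carbon, and the small step concerns the halogen. Going by the values given here, there is therefore no measured step that bears directly on this change, and the expectation rests on the number of compound 1 alone. For compound 4 the expected step is a number 1.5 percentage points higher from compound 1 to compound 4 (within the scatter), that is, none beyond the scatter. Compound 4 is thus expected to give about 41% in this assay, in the range 26% to 58%.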

Compound 4, a percentage reported as activity, at one concentration (the size of the read-out at that concentration, not a potency): 84.4%
Beside the measured number, compound 4's estimate is 43.4 percentage points below it; the whole stated range lies below it.
By their numbers in this assay, from the lowest: compound 1; then compounds 2, 3 and 4 (each within the scatter of the next).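

For the compounds shown here, the acetyl of compound 1, which no earlier step had touched, proves to be no silent place: with the 3-bromophenoxy group kept, methyl in place of hydrogen on a saturated chain carbon bound to a carbonyl carbon gives a number 44.9 percentage points higher from compound 1 to compound 4 (beyond the scatter) in this assay. The earlier steps shown here concerned only the group on the other carbonyl carbon and the halogen, so they could not show that going from acetyl to propanoyl, a change of a single carbon with no ring, no hydrogen-bond donor or acceptor and no net charge, is enough for a large step. Nothing shown here accounts for the size of this step.

The compounds shown leave open how a longer chain such as butanoyl, or an amine or a carboxylic acid, would read at this place. They also leave open whether the same methyl would give a step of this size on the compound 3 scaffold, with the (3-bromophenyl)sulfanyl group on the carbonyl carbon, and how either compound would read at other concentrations.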